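A few compounds are considered here, and "the series" means these few. Any claim that something is new, unique, unknown or untested is made for them only; others in the source may bear on it.

Measured so far in a functional assay, tested at 75 ug/mL; on this read-out higher numbers stand for a stronger effect at the one concentration tested and lower numbers for a weaker effect:
compound 1 `O=S(=O)(CC1=NCCO1)C1C(c2ccc(Cl)cc2)=NN(c2ccccc2)C1c1ccc(Cl)cc1` gives "not active" (no number reported)
compound 2 `COc1ccc(C2=NN(c3ccccc3)C(c3ccc(C)cc3)C2S(=O)(=O)CC2=NCCO2)cc1` gives 64.3%
compound 3 `O=S(=O)(CC1=NCCS1)C1C(c2ccccc2)=NOC1c1ccccc1` gives "not active" (no number reported)

Going by the values given here, compound 2 stands alone as the only entry with a number in this assay; the other two entries carry no number at all. Compound 4 `COc1ccc(C2=NN(c3ccccc3)C(c3ccc(C)cc3)C2S(=O)(=O)CC2=NCCS2)cc1` is not yet measured. It differs from compound 2 by a group of 5 heavy atoms (3 carbon, 1 nitrogen, 1 sulfur; one five-membered non-aromatic ring with 2 hetero atoms) in place of a group of 5 heavy atoms (3 carbon, 1 nitrogen, 1 oxygen; one five-membered non-aromatic ring with 2 hetero atoms), on a saturated chain carbon bound to a sulfonyl sulfur. Among the compounds with values here, no step between measured compounds is available for this change, and compound 1 and compound 3 share neither the core nor the substituents of compound 2, so their entries give no usable direction. The step is expected to be small, within the scatter or a modest loss at most, as a number 9.3 percentage points lower from compound 2 to compound 4 (within the scatter). Compound 4 is therefore estimated at 55%, in the range 20% to 80%, with a real chance that only a limit is reported.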

Compound 4, a percentage reported as activity, at one concentration (the size of the read-out at that concentration, not a potency): 43.9%
The estimate for compound 4 lay 11.1 percentage points above the measured number; measured number inside the range.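

On the shared core, the change at this place gives a number 20.4 percentage points lower from compound 2 to compound 4 (beyond the scatter) in this assay, the first step readable in the series. The position on a saturated chain carbon bound to a sulfonyl sulfur therefore responds to exchanging ring oxygen for ring sulfur, yet compound 4 still gives a number rather than a "not active" entry. Nothing available accounts for this difference.

Going by these compounds, how an open-chain amine or a carboxylic acid would read out at this place remains open. Whether the same exchange gives a similar step on another core is also unresolved.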